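Methoxy for Chloro on Two Related Cores

This account rests on a few compounds, and the source may have more. Where it says the series, first, only, none or still open, it means among the compounds named here.

Compound 1 `COc1ccc(-c2cc3cc(C)ccc3c(N3CCN(C)CC3)n2)cc1` and compound 2 `Cc1ccc2c(N3CCN(C)CC3)nc(-c3ccc(Cl)cc3)cc2c1` share one core and differ at a single point. In a functional assay on SK-OV-3 cells (Homo sapiens) for cytotoxicity (on this read-out higher numbers stand for weaker inhibition and lower numbers for stronger inhibition), compound 2 gives 5750 nM, and compound 1 gives 7940 nM. The change between them is methoxy in place of chloro on an aromatic carbon, and it produced a 1.4-fold higher number from compound 2 to compound 1 (0.14 log units; within the scatter). Compound 3 `CN1CCN(c2nc(-c3ccc(Cl)cc3)cc3c(N(C)C)cccc23)CC1` is built on a different core; how the two cores differ is not broken down here. In this assay compound 3 gives 7560 nM, a number that sits close to those of compound 1 and compound 2. Compound 4 `COc1ccc(-c2cc3c(N(C)C)cccc3c(N3CCN(C)CC3)n2)cc1` has not yet been measured and stands to compound 3 as compound 1 stands to compound 2: the change is methoxy in place of chloro on an aromatic carbon, with an identical description of its place, so it is the same change carried onto the second core. Among the compounds with values here, the one precedent for it stayed within the scatter. Because that same change gave a 1.4-fold higher number from compound 2 to compound 1 (0.14 log units; within the scatter), compound 4 is expected to show a 1.3-fold higher number from compound 3 to compound 4 (0.12 log units; within the scatter) in this assay. Compound 4 is therefore estimated at 10000 nM, with a likely range from 5000 nM to 25000 nM.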

Compound 4, half-maximal inhibitory concentration: 13200 nM
Compound 4: the middle estimate sits 1.3-fold (0.12 log units) below what was measured, within the range that was stated.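

On the second core, the change from 4-chlorophenyl to 4-methoxyphenyl gave a 1.7-fold higher number from compound 3 to compound 4 (0.24 log units; within the scatter) in this assay. Set beside the step on the first core, the new step shows no difference between the two cores: the same change on two cores in this assay, a 1.4-fold higher number (0.14 log units; within the scatter) from compound 2 to compound 1 and a 1.7-fold higher number (0.24 log units; within the scatter) from compound 3 to compound 4, 1.3-fold (0.10 log units) apart, within the scatter of two such steps. The change therefore carried across this one pair of cores without any distinguishable dependence on the core, but each step lies within the scatter on its own, so the data do not show that methoxy in place of chloro shifts the number on either core, and two cores are too few to support a rule for the wider series.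

The compounds shown carry only chloro and methoxy at this place on the aromatic ring, so it remains open whether an amine, a carboxylic acid or a longer alkoxy chain there would move the number beyond the scatter. Going by these compounds, it also remains open whether the same change would behave alike on a third core or outside this assay.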